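Compound 4: fluoro in place of hydrogen, cytotoxicity outlook

The source may report more compounds than this note shows. Statements on the series, on what has been measured and on what is new or still open speak of the compounds shown alone.

Measured so far in an ADME assay on HEK293 cells (Homo sapiens) for cytotoxicity, read by sulforhodamine B assay, with a stated time of 48 h, tested at 10 uM; on this read-out lower numbers stand for less inhibition and higher numbers for more inhibition at the one concentration tested (going by the name of the read-out):
compound 1 `CCCCCCc1cn(C(c2ccccc2)c2cc3cc(Br)ccc3nc2OC)nn1` — -3.17%
compound 2 `COc1nc2ccc(Br)cc2cc1C(c1ccccc1)n1cc(-c2ccccc2)nn1` — 8.25%
compound 3 `COc1nc2ccc(Br)cc2cc1C(c1ccccc1)n1cc(CCO)nn1` — 4.54%

Compound 2 gives the highest of the three numbers in this assay. Going by the values given here, its gap to compound 3 is small, a number 3.7 percentage points lower from compound 2 to compound 3 (within the scatter), and lies within the scatter; its gap to compound 1, a number 11.4 percentage points higher from compound 1 to compound 2 (beyond the scatter), is the only step in the set beyond the scatter, and that step is modest. The third step, a number 7.7 percentage points higher from compound 1 to compound 3 (within the scatter), is also within the scatter.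

Compound 4 `COc1nc2ccc(Br)cc2cc1C(c1ccccc1)n1cc(-c2ccc(F)cc2)nn1` is the next compound. Against compound 2 the change is fluoro in place of hydrogen on an aromatic carbon. Among the compounds with values here, no measured step swaps a single ring hydrogen for a fluorine; the steps that exist replace the whole group on that aromatic carbon, and even those moved this assay by at most a modest amount. The change from compound 2 to compound 4 is far smaller than any of them, so compound 4 is expected to sit close to compound 2, with a step of a number 0.8 percentage points higher from compound 2 to compound 4 (within the scatter) expected to fall within the scatter. Compound 4 is therefore estimated at 9%, with a range from 0% to 18%.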

Compound 4, a percentage reported as inhibition, at one concentration (the size of the read-out at that concentration, not a potency): 4.04%
For compound 4 the middle estimate is 5 percentage points above the measured one, within the range that was stated.
By their numbers in this assay, from the lowest: compounds 1, 4, 3 and 2 (each within the scatter of the next, the first and the last beyond it).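

In this assay, going by these compounds alone, phenyl to 4-fluorophenyl gives a number 4.2 percentage points lower from compound 2 to compound 4 (within the scatter) and is the first single-atom change at this position, which leaves the read-out within the scatter. Hexyl differs here: phenyl in its place gave a number 11.4 percentage points higher from compound 1 to compound 2 (beyond the scatter) while 4-fluorophenyl in its place gives a number 7.2 percentage points higher from compound 1 to compound 4 (within the scatter) and so, unlike phenyl, stays within the scatter, and 4-fluorophenyl in place of 2-hydroxyethyl gives a number 0.5 percentage points lower from compound 3 to compound 4 (within the scatter) as a further step within it. Nothing available explains the size of any of these steps.

Open, going by these compounds, is whether a group larger than fluoro on the phenyl ring, such as a carboxylic acid or an amine, would move the read-out beyond the scatter. Also open, on these data alone, is how a chain longer than hexyl would read against 4-fluorophenyl.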